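Exchanging One Aromatic Ring, Cytotoxicity Still to Be Measured

A few compounds are considered here, and "the series" means these few. Any claim that something is new, unique, unknown or untested is made for them only; others in the source may bear on it.

Of the compounds shown here, three have been tested so far in an ADME assay on HUVEC cells (Homo sapiens) for cytotoxicity, read by MTT assay, with a stated time of 48 h; a higher number here means a weaker inhibitor, a lower number a stronger inhibitor. Compound 1 `Cc1ccc(NC(=S)OCCNC(=O)C(C)(C)Oc2ccc(Cl)cc2)cc1` gives 661000 nM in this assay, and compound 2 `COc1ccc(NC(=S)OCCNC(=O)c2cccnc2)cc1` gives 550000 nM; these two numbers lie within the usual scatter of each other. Compound 3 `O=C(CCCCC1CCSS1)OCCCOC(=O)c1cccnc1` did not yield a number in this assay but only a limit, > 800000 nM. That puts compound 3 at the limit of > 800000 nM in this assay, at which 1 of the 3 values shown sits, the edge of what this assay can report, so its true position is known only as a range.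

Compound 4 `Cc1cnc(C(=O)OCCCOC(=O)CCCCC2CCSS2)c[n+]1[O-]` is the next candidate. It differs from compound 3 at a single spot: a group of 8 heavy atoms (5 carbon, 2 nitrogen, 1 oxygen; one six-membered aromatic ring with 2 hetero atoms) in place of a group of 6 heavy atoms (5 carbon, 1 nitrogen; one six-membered aromatic ring with 1 hetero atom), on a carbonyl carbon. Within the data shown here, no step between two measured compounds is available here, so there is no measured change of this kind to lean on. What the three measured values do show is that all of them sit at the weak end of this assay, and compound 3 itself reached the limit. On that basis no shift beyond the scatter is expected for compound 4; the step from compound 3 to compound 4 is estimated as a number no higher from compound 3 to compound 4 (the limit leaves the size open). For compound 4 the expected value is therefore 800000 nM, in a range from 400000 nM to 1600000 nM, and a limit rather than a number is the more likely report.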

Compound 4, half-maximal inhibitory concentration: > 800000 nM
Compound 4 ended at the assay's limit (the forecaster's own chance of this, stated with the estimate: 65%); the middle value sits exactly at the limit.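

In this assay compound 3 and compound 4 both end at a limit rather than a number, so no step between them can be read: the limit of > 800000 nM in this assay, at which 2 of the 4 values shown sit.

The compounds shown leave open where the true values of compound 3 and compound 4 lie, and whether exchanging the pyridin-3-yl group changes the cytotoxicity at all.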